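Chlorinated purine analogues tested on HT-29 colon cells

A few compounds are considered here, and "the series" means these few. Any claim that something is new, unique, unknown or untested is made for them only; others in the source may bear on it.

Four compounds share a bicyclic core bearing a chloro group, linked through a benzyl arm that itself carries a chloromethyl group. Compound 1 `ClCc1ccccc1Cn1cnc2c(Cl)nc(Cl)nc21` and compound 2 `ClCc1ccccc1Cn1cnc2c(Cl)ncnc21` carry the arm in one arrangement; compound 3 `ClCc1cccc(Cn2cnc3c(Cl)ncnc32)c1` and compound 4 `ClCc1cccc(Cn2cnc3c(Cl)nc(Cl)nc32)c1` carry it in another, and the difference between the two cores is not broken down here.

In a functional assay on HT-29 cells (Homo sapiens) for cytotoxicity, read by sulforhodamine B assay, with a stated time of 48 h (a lower number here means that less compound is tolerated, a higher number that more compound is tolerated), compound 1 gives > 100000 nM, which is a limit of the assay rather than a measured number. In this assay compound 2 likewise gives only a limit, > 100000 nM. In this assay compound 3 also gives a limit, > 100000 nM. Every value therefore sits at the limit of > 100000 nM in this assay, at which 3 of the 3 values shown sit.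

Compound 1 differs from compound 2 by chloro in place of hydrogen on an aromatic carbon. The step that the two limits leave unreadable from compound 2 to compound 1 cannot be read, since both ends are limits. Compound 4 differs from compound 3 by exactly the same change, (chloro in place of hydrogen on an aromatic carbon), made on the other core.

Compound 4 has not yet been tested in this assay. It is expected to behave like the others, with 150000 nM as the estimate, resting on compound 3 sitting at > 100000 nM and on the unreadable step that the two limits leave unreadable from compound 2 to compound 1. The expected step that the limit leaves unreadable from compound 3 to compound 4 is thus essentially none, and a further limit rather than a number is the likeliest outcome.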

Compound 4, concentration lethal to 50% of the cells: > 100000 nM
Compound 4: no number, only a limit; the forecaster's own chance of this, stated with the estimate: 85%; the middle value is on the limit's open side.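

Compound 3 and compound 4 both give a limit rather than a number in this assay, so the step between them, chloro in place of hydrogen on an aromatic carbon, cannot be read: the limit of > 100000 nM in this assay, at which 4 of the 4 values shown sit.

The compounds shown leave open what lethal concentration any of them has in this assay, and whether adding this chloro changes that concentration on either core.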